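A few compounds are considered here, and "the series" means these few. Any claim that something is new, unique, unknown or untested is made for them only; others in the source may bear on it.

Going by the values given here, in a functional assay on HCT-116 cells (Homo sapiens) for antiproliferative activity, read by MTT assay, with a stated time of 24 h (on this read-out lower numbers stand for stronger inhibition and higher numbers for weaker inhibition), compound 1 (`C#CCOc1ccc2c(=O)c(-c3cc(OC)c(OC)cc3OC)coc2c1`) gives 8050 nM, while compound 2 (`COc1cc(OC)c(-c2coc3cc(OCc4ccccc4C)ccc3c2=O)cc1OC`) gives 2900 nM, the lower of the two numbers so far. Compound 3 (`COc1cc(OC)c(-c2coc3cc(OCc4ccccc4C(F)(F)F)ccc3c2=O)cc1OC`) differs from compound 2 in one place, with trifluoromethyl in place of methyl on an aromatic carbon, ortho to a large group (trifluoromethyl in place of methyl on an aromatic carbon). Among the compounds with values here, the only measured step, a 2.8-fold lower number from compound 1 to compound 2 (0.44 log units; beyond the scatter), is modest; it brought in the 2-methylphenyl group but shows nothing about changing its methyl. No change beyond the scatter is therefore expected, and the estimated step is a 1.2-fold lower number from compound 2 to compound 3 (0.06 log units; within the scatter). For compound 3, the estimate is 2500 nM, with an expected range of 900 nM to 7000 nM.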

Compound 3, half-maximal inhibitory concentration: 4760 nM
Compound 3: the middle estimate sits 1.9-fold (0.28 log units) below what was measured, within the range that was stated.
By their numbers in this assay, from the lowest: compounds 2, 3 and 1 (each within the scatter of the next, the first and the last beyond it).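

On an aromatic carbon ortho to a large group, this assay shows a 1.6-fold higher number from compound 2 to compound 3 (0.22 log units; within the scatter) for trifluoromethyl in place of methyl, so this assay does not tell these two groups apart here. Against the ethynyl group, the 2-(trifluoromethyl)phenyl group shows a 1.7-fold lower number from compound 1 to compound 3 (0.23 log units; within the scatter), whereas the 2-methylphenyl group had given a step beyond the scatter. No measurement at hand bears on the reason for this result. The compounds shown leave open what an amine, a carboxylic acid or a methoxy group would give on this same carbon.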